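Propyl for hydrogen on the triazole carbon of compound 3

The source may hold more compounds than are shown below. What is called first, only, known or untested is meant among the compounds shown, and "the series" means these compounds.

Of the compounds shown here, three sharing one core have been measured in a functional assay on FTC-133 cells (Homo sapiens) for cytotoxicity, read by MTT assay, with a stated time of 24 h; a lower number here means a stronger inhibitor, a higher number a weaker inhibitor. Compound 1 `CCCc1cn([C@H]2C[C@H](CO)N(C)O2)nn1` gives 3870 nM. Compound 2 `CN1O[C@H](n2cc(-c3ccccc3)nn2)C[C@@H]1CO` gives 6330 nM, and compound 3 `CN1O[C@H](n2ccnn2)C[C@@H]1CO` gives 6300 nM. On these numbers compound 3 stands second highest of the three; its nearest neighbour is compound 2, whose value lies within the scatter of it, and its furthest is compound 1, whose value also lies within the scatter of it. Among the measured compounds shown here, the one step that can be traced, a 1.0-fold lower number from compound 2 to compound 3 (0.00 log units; within the scatter), shows that removing a large group from that aromatic carbon left the number essentially unchanged.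

Compound 4 `CCCc1cn([C@@H]2C[C@H](CO)N(C)O2)nn1` is the next case. The change from compound 3 is propyl in place of hydrogen on an aromatic carbon. For the measured compounds named here, no measured step reports exactly this change, since compound 1 carries the same propyl group at that place but on a differently configured core, so only its value can be set beside that of compound 3, and the two lie within the scatter of each other. Both pieces of evidence point to a small effect. Compound 4 is therefore expected to show a step of a 1.3-fold lower number from compound 3 to compound 4 (0.10 log units; within the scatter) in this assay, with an estimated value of 5000 nM, somewhere between 2500 nM and 10000 nM.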

Compound 4, half-maximal inhibitory concentration: 4710 nM
Estimate against measurement, compound 4: 1.1-fold (0.03 log units) above, and the stated range covers the measured number.
By their numbers in this assay, from the lowest: compounds 1, 4, 3 and 2 (each within the scatter of the next).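

In this assay, propyl on this aromatic carbon of the five-membered ring now has a direct reading against hydrogen, a 1.3-fold lower number from compound 3 to compound 4 (0.13 log units; within the scatter), and against phenyl, a 1.3-fold lower number from compound 2 to compound 4 (0.13 log units; within the scatter). With the earlier step between phenyl and hydrogen, this means that all three substituents at this carbon give values within the scatter of one another, so on compounds 2, 3 and 4 the number does not follow the size of the group placed there. The result also adds the first reading of configuration, a 1.2-fold higher number from compound 1 to compound 4 (0.09 log units; within the scatter), which is again within the scatter and shows that a different drawn stereocentre at a saturated ring carbon does not separate the two numbers in this assay: the fact that compounds 1 and 4 differ only in the configuration as drawn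

On these data alone, whether an amine, a carboxylic acid or a longer chain on this aromatic carbon would give a step beyond the scatter stays open. Among the compounds shown here, the one pair that differs in configuration carries propyl, and whether the same holds with phenyl or hydrogen at this carbon also stays open.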